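This account rests on a few compounds, and the source may have more. Where it says the series, first, only, none or still open, it means among the compounds named here.

Measured set:
Compound 1 `Cc1ccc(-c2ccnc(Nc3ccc4c(c3)c(/C=C3/C(=O)Nc5ccccc53)cn4C)n2)cc1`; in a functional assay on PA-1 cells (Homo sapiens) for cytotoxicity, read by MTT assay, with a stated time of 48 h (a higher number here means a weaker inhibitor, a lower number a stronger inhibitor), compound 1 gives > 100000 nM, which is a limit of the assay and not a number.
Compound 2 `COc1ccc(-c2ccnc(Nc3ccc4c(c3)c(/C=C3/C(=O)Nc5ccccc53)cn4C)n2)cc1`; in this assay compound 2 gives > 100000 nM, also a limit of the assay and not a number.
Compound 3 `Cn1cc(/C=C2/C(=O)Nc3ccccc32)c2cc(Nc3nccc(-c4ccc(Cl)cc4)n3)ccc21`; in this assay compound 3 gives 2430 nM.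

Going by the values given here, compound 3 thus holds the only number; the other two values sit at the limit (the limit of > 100000 nM in this assay, at which 2 of the 3 values shown sit). The change from compound 1 to compound 2 gives a step that the two limits leave unreadable from compound 1 to compound 2. The change to the chloro compound gives an at least 41-fold lower number from compound 1 to compound 3 (1.61 log units; beyond the scatter) and an at least 41-fold lower number from compound 2 to compound 3 (1.61 log units; beyond the scatter).

Compound 4 `Cn1cc(/C=C2/C(=O)Nc3ccccc32)c2cc(Nc3nccc(-c4ccc(Cl)cc4Cl)n3)ccc21` is not yet measured. It differs from compound 3 by chloro in place of hydrogen on an aromatic carbon. Among the compounds with values here, none of the measured steps adds a second chloro group; they only exchange the single substituent on the same ring, so they do not read directly on this step. With chloro already established as the substituent that gives a number, the added chloro is expected to leave the value near that of compound 3, with no step beyond the scatter: the expected step is a 1.2-fold lower number from compound 3 to compound 4 (0.08 log units; within the scatter). Compound 4 is therefore estimated at 2000 nM, within 600 nM to 7000 nM.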

Compound 4, half-maximal inhibitory concentration: > 100000 nM
Compound 4: no number, only a limit; the forecaster's own chance of this, stated with the estimate: 10%; middle value at least 50-fold (1.69 log units) from the limit.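

In this assay, a second chloro group on the ring carbon ortho to a large group and meta to the first chloro group, the change from 4-chlorophenyl to 2,4-dichlorophenyl, gives an at least 41-fold higher number from compound 3 to compound 4 (1.61 log units; beyond the scatter). Going by these compounds alone, the earlier steps only exchanged the single substituent on this ring and singled out chloro as the one group of the three to give a number; this step shows that a chloro group on that ring does not by itself keep a number, and that the ortho carbon is not a neutral place for a further group. Compound 4 gives a limit and not a number, and the series now stands mostly at that limit: the limit of > 100000 nM in this assay, at which 3 of the 4 values shown sit.

The steps from compound 1 and from compound 2 to compound 4 cannot be read, as both ends of each are limits. Within the data shown here, whether a fluoro group or an amine on the same ortho carbon would keep a number stays open, as does whether the ortho carbon alone or the pairing of two chloro groups matters, since no compound here carries a single ortho group.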